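The source may hold more compounds than are shown below. What is called first, only, known or untested is meant among the compounds shown, and "the series" means these compounds.

Three members of the series have been run in a functional assay on HepG2 cells (Homo sapiens) for antiproliferative activity, read by MTT assay, with a stated time of 48 h; a higher number here means a weaker inhibitor, a lower number a stronger inhibitor. Compound 1 `COc1ccc(-n2nncc2CN2C(=O)C3(C(C#N)=C(N)Oc4c3c3nc5ccccc5nc3c3ccccc43)c3ccccc32)cc1` carries a 4-methoxyphenyl on an aromatic nitrogen; in this assay compound 1 reaches only the limit of > 50000 nM. Compound 2 `COc1ccccc1-n1nncc1CN1C(=O)C2(C(C#N)=C(N)Oc3c2c2nc4ccccc4nc2c2ccccc32)c2ccccc21` keeps the shared core with 2-methoxyphenyl in its place; in this assay compound 2 likewise stops at the limit of > 50000 nM. The change 2-methoxyphenyl in place of 4-methoxyphenyl on an aromatic nitrogen thus yields a step that the two limits leave unreadable from compound 1 to compound 2. Compound 3 `COc1ccc(-n2nncc2CN2C(=O)C3(C(C#N)=C(N)Oc4c(N)cc5nc6ccccc6nc5c43)c3ccccc32)cc1` has another core; the difference between the two cores is not broken down here. In this assay compound 3 also sits at the limit of > 50000 nM. Going by the values given here, every value so far rests at the limit of > 50000 nM in this assay, at which 3 of the 3 values shown sit, so neither the substituent swap nor the core change can be read. Compound 4 `COc1ccccc1-n1nncc1CN1C(=O)C2(C(C#N)=C(N)Oc3c(N)cc4nc5ccccc5nc4c32)c2ccccc21` remains to be measured; it arises from compound 3 by 2-methoxyphenyl in place of 4-methoxyphenyl on an aromatic nitrogen, the same change as from compound 1 to compound 2, with the place described in identical words. The expected step is a number no higher from compound 3 to compound 4 (the limit leaves the size open), which rests on the earlier swap having given a step that the two limits leave unreadable from compound 1 to compound 2. For compound 4 the expected value is 50000 nM, within an estimated range from 15000 nM to 200000 nM, most likely again only a limit.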

Compound 4, half-maximal inhibitory concentration: > 50000 nM
Compound 4: a limit, no number; the forecaster's own chance of this, stated with the estimate: 85%; the middle value lies on the limit itself.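

In this assay compound 4 gives > 50000 nM, a limit and not a number, so the swap from compound 3 to compound 4 yields no readable step, and the series stays at one value: the limit of > 50000 nM in this assay, at which 4 of the 4 values shown sit.

The compounds shown leave open whether the methoxyphenyl swap or the difference between the two cores changes antiproliferative activity at all.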